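The source may report more compounds than this note shows. Statements on the series, on what has been measured and on what is new or still open speak of the compounds shown alone.

The measured compounds and their values:
compound 1 `COc1ccc(-n2ccnc2SCC(=O)Nc2ccccc2[N+](=O)[O-])cc1` gives 161000 nM in an ADME assay on MT4 cells (Homo sapiens) for cytotoxicity, read by MTT assay; a higher number here means that more compound is tolerated, a lower number that less compound is tolerated
compound 2 `O=C(CSc1nccn1-c1cccc2ccccc12)Nc1ccccc1F` gives 34700 nM in this assay
compound 3 `COc1ccc(-n2ccnc2SCC(=O)Nc2ccccc2Cl)cc1` gives > 334000 nM in this assay, which is a limit of the assay and not a number

Compound 2 stands lowest of the two numbers shown, with compound 1 sitting higher by a margin beyond the scatter. Compound 4 `O=C(CSc1nccn1-c1cccc2ccccc12)Nc1ccccc1Cl` differs from compound 2 by chloro in place of fluoro on an aromatic carbon. Among the measured compounds shown here, the one measured step, an at least 2.0-fold higher number from compound 1 to compound 3 (0.31 log units; beyond the scatter), concerns a different exchange and rests on (the limit of > 334000 nM in this assay, at which 1 of the 3 values shown sits), so it speaks only loosely to the present change. For the measured compounds named here, with no close precedent, a step of no more than a 1.3-fold higher number from compound 2 to compound 4 (0.11 log units; within the scatter) is expected, within the scatter. Compound 4 is therefore estimated at 45000 nM, in the range 18000 nM to 110000 nM.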

Compound 4, half-maximal cytotoxic concentration: 35200 nM
Estimate against measurement, compound 4: 1.3-fold (0.11 log units) above, and the stated range covers the measured number.
By their numbers in this assay, from the lowest: compounds 2 and 4 (each within the scatter of the next); then compound 1. At a limit, above all of these: compound 3.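

In this assay, chloro in place of fluoro on an aromatic carbon gives a 1.0-fold higher number from compound 2 to compound 4 (0.01 log units; within the scatter), so this exchange at this position leaves no readable mark on the number. Unlike the earlier step from nitro to chloro, this one rests on two numbers and not on a limit. Nothing measured here accounts for the result.

Going by these compounds, whether the same exchange behaves alike on the core of compound 1 stays open. So does what an amine or a carboxylic acid on this aromatic carbon would give.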